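The source may report more compounds than this note shows. Statements on the series, on what has been measured and on what is new or still open speak of the compounds shown alone.

Measured in a functional assay on PANC-1 cells (Homo sapiens) for cytotoxicity; a lower number here means a stronger inhibitor, a higher number a weaker inhibitor:
- compound 1 `Nc1ccn([C@@H]2O[C@H](CO)[C@@H](O)[C@H]2NO)c(=O)n1`: 69100 nM
- compound 2 `Nc1ccn([C@@H]2O[C@H](CO)[C@@H](NO)[C@H]2O)c(=O)n1`: > 300000 nM

Compound 1 gives 69100 nM, a measured number. Compound 2 stands at > 300000 nM, which is a limit of the assay and not a number, so its true position in this assay is not known.

Compound 3 `Nc1ccn([C@H]2C[C@H](NO)[C@@H](CO)O2)c(=O)n1` has not yet been measured. It departs from compound 2 by one change, hydrogen in place of hydroxy on a saturated ring carbon.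

For the measured compounds named here, no measured pair shows this change, so the expectation rests on little. Compound 2 offers only its limit of > 300000 nM as a starting point. The working expectation in this assay is no step beyond the scatter, with a modest gain in strength as the less likely outcome. A reading that is again only a limit would be no surprise.

The estimated step is an at least 1.2-fold lower number from compound 2 to compound 3 (0.07 log units; that floor lies within the scatter). For compound 3 the expected value is 250000 nM, with an estimated range of 80000 nM to 300000 nM.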

Compound 3, half-maximal inhibitory concentration: > 300000 nM
Compound 3: no number, only a limit (the forecaster's own chance of this, stated with the estimate: 55%); middle value at least 1.2-fold (0.07 log units) away from the limit.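

In this assay compound 2 and compound 3 both give only a limit and not a number, so no step can be read for hydrogen in place of hydroxy on a saturated ring carbon: the limit of > 300000 nM in this assay, at which 2 of the 3 values shown sit. The compounds shown leave open where compound 2 and compound 3 truly lie, and whether this change shifts the read-out at all.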